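The source may report more compounds than this note shows. Statements on the series, on what has been measured and on what is new or still open speak of the compounds shown alone.

In a functional assay on HT-29 cells (Homo sapiens) for cytotoxicity, read by MTT assay, with a stated time of 72 h (a higher number here means a weaker inhibitor, a lower number a stronger inhibitor), compound 1 (`CN(C)CCn1cnnc1-c1cc(Oc2ccc(NC(=O)N/N=C/c3cc(C(C)(C)C)cc(C(C)(C)C)c3O)cc2F)ccn1`) gives 680 nM, and compound 2 (`CN(C)CCn1cnnc1-c1cc(Oc2ccc(NC(=O)N/N=C/c3ccc(O)c(Br)c3)cc2F)ccn1`) gives 450 nM. The two numbers lie within the scatter of each other, so neither compound can be called the more potent. Compound 3 (`CN(C)CCn1cnnc1-c1cc(Oc2ccc(NC(=O)N/N=C/c3cccc(Cl)c3Cl)cc2F)ccn1`) carries 2,3-dichlorophenyl in place of 3-bromo-4-hydroxyphenyl on a carbon with a double bond to nitrogen. Both measured compounds bear a hydroxyl group on that ring, and compound 3 does not, so a modest loss is expected rather than a gain. The step from compound 2 to compound 3 is estimated at a 2.0-fold higher number from compound 2 to compound 3 (0.30 log units; within the scatter). For compound 3 the expected value in this assay is 900 nM, within a range from 350 nM to 2500 nM.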

Compound 3, half-maximal inhibitory concentration: 130 nM
For compound 3 the middle estimate is 6.9-fold (0.84 log units) above the measured one; the whole stated range lies above it.
By their numbers in this assay, from the lowest: compound 3; then compounds 2 and 1 (each within the scatter of the next).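

In this assay the swap of 3-bromo-4-hydroxyphenyl for 2,3-dichlorophenyl on a carbon with a double bond to nitrogen gives a 3.5-fold lower number from compound 2 to compound 3 (0.54 log units; beyond the scatter) and so shows that a hydroxyl on this ring is not needed for a low number. The swap removes the hydroxyl and exchanges bromine for two chlorines in one step, so the gain cannot be assigned to any one of these changes. No measurement here accounts for the step. From the compounds shown here alone, whether a single chlorine would do as well stays open, as does the outcome with a methoxy group or an amine on this ring.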